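A 1,3-thiazol-2-yl swap in a cell toxicity test

The source may hold more compounds than are shown below. What is called first, only, known or untested is meant among the compounds shown, and "the series" means these compounds.

Compound 1 `Cc1ccc(CNc2nc(N)nc3ccn(Cc4ccccn4)c23)nc1` gives > 24000 nM (a limit)
Compound 2 `Cc1nnc(CNc2nc(N)nc3ccn(Cc4ccccn4)c23)o1` gives > 24000 nM (a limit)
Compound 3 `Nc1nc(NCc2ncco2)c2c(ccn2Cc2ccccn2)n1` gives > 24000 nM (a limit)

All three compounds were tested in an ADME assay on HEK293 cells (Homo sapiens) for cytotoxicity, read by ATP content, with a stated time of 6 h; on this read-out lower numbers stand for higher toxicity in this test and higher numbers for lower toxicity in this test. None of the three has an exact value, and each result above is a limit rather than a number. Compound 3 therefore has no rank within the set, which shares a single mark: the limit of > 24000 nM in this assay, at which 3 of the 3 values shown sit.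

Compound 4 `Nc1nc(NCc2nccs2)c2c(ccn2Cc2ccccn2)n1` differs from compound 3 in one group: 1,3-thiazol-2-yl in place of 1,3-oxazol-2-yl on a saturated chain carbon bound to a nitrogen on an aromatic ring. Here 1,3-thiazol-2-yl stands in place of 1,3-oxazol-2-yl on a saturated chain carbon bound to a nitrogen on an aromatic ring.

Swaps at this same place have been measured. They include a step that the two limits leave unreadable from compound 1 to compound 2 and also a step that the two limits leave unreadable from compound 1 to compound 3. The closest guide is a step that the two limits leave unreadable from compound 2 to compound 3, and with that as the basis, no step beyond the scatter is expected in either direction. Another limit is the likeliest result in this assay.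

The expected size of the change is a step that the limit leaves unreadable from compound 3 to compound 4. Compound 4 is estimated at 26000 nM, with an expected range from 12000 nM to 50000 nM.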

Compound 4, half-maximal cytotoxic concentration: > 24000 nM
Compound 4: no number, only a limit; the forecaster's own chance of this, stated with the estimate: 85%; the middle value lies beyond the limit too.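

Compound 4, like compounds 1, 2 and 3, gives only a limit in this assay, so no step among these four compounds can be read, and all four share one mark: the limit of > 24000 nM in this assay, at which 4 of the 4 values shown sit.

The compounds shown leave open whether the groups swapped at this place differ at all in this assay, and how far beyond the limit each compound lies.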